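Compound 3 and a longer side chain

The source may report more compounds than this note shows. Statements on the series, on what has been measured and on what is new or still open speak of the compounds shown alone.

Measured in a functional assay for inhibition, with Sus scrofa as the target; on this read-out lower numbers stand for stronger inhibition and higher numbers for weaker inhibition:
- compound 1 `CC1(C)Oc2ccc(C#N)cc2[C@@H](Oc2ccccn2)[C@]1(C)O`: 6000 nM
- compound 2 `CC1(C)Oc2ccc(C#N)cc2[C@@H](Oc2ccnc(O)c2)[C@]1(C)O`: 4 nM
- compound 3 `CC1(C)Oc2ccc(C#N)cc2[C@@H](Oc2ccc(=O)[nH]n2)[C@@]1(O)Cc1ccccc1`: > 100000 nM (a limit of the assay, not a number)

Compound 3 has no exact value, only a limit. It is one of the values shown, and (the limit of > 100000 nM in this assay, at which 1 of the 3 values shown sits).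

Compound 4 `CC1(C)Oc2ccc(C#N)cc2[C@@H](Oc2ccc(=O)[nH]n2)[C@@]1(O)COC(=O)c1ccccc1` is made from compound 3 by one change: benzoyloxy in place of phenyl on a saturated chain carbon bound to a saturated ring carbon. In words, benzoyloxy stands in place of phenyl on a saturated chain carbon bound to a saturated ring carbon.

Going by the values given here, only one measured step can serve as a guide, and it is a 1500-fold lower number from compound 1 to compound 2 (3.18 log units; beyond the scatter). That step is large, so a single change can move this read-out a long way. However, it replaces the group on oxygen rather than anything on this chain, so it sets no size for the present change. Among the compounds with values here, compound 4 keeps the group on oxygen found in compound 3, and no measured step touches the chain.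

The expectation is therefore cautious: a modest move towards a lower number in this assay, or none that can be read, since compound 4 may also return only a limit. The expected change is an at least 1.2-fold lower number from compound 3 to compound 4 (0.09 log units; that floor lies within the scatter). For compound 4 the estimated value is 80000 nM, with an expected range from 10000 nM to 200000 nM.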

Compound 4, half-maximal inhibitory concentration: > 100000 nM
Compound 4: a limit, no number; the forecaster's own chance of this, stated with the estimate: 50%; at least 1.2-fold (0.09 log units) between middle value and limit.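

Compound 3 and compound 4 both return only a limit of the assay in this assay, not a number, so no step between them can be read: the limit of > 100000 nM in this assay, at which 2 of the 4 values shown sit.

The compounds shown leave open whether benzoyloxy in place of phenyl on a saturated chain carbon bound to a saturated ring carbon moves this read-out at all, and in which direction.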